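Dimethylpyridin-3-yl isomers: from compound 2 to compound 3

The compounds below may be only part of what the source reports. "The series", "measured", "known", "first", "only" and "open" are said of these compounds alone.

Among the measured compounds shown here, the series so far holds two measured compounds, compound 1 (`Cc1ccc([C@H](C(=O)N(C)C)N2C(=O)[C@@H](C3Cc4ccccc4C3)NC(=O)[C@H]2CC(C)C)cn1`) and compound 2 (`CC[C@H](C)[C@@H]1C(=O)N[C@H](C2Cc3ccccc3C2)C(=O)N1[C@@H](C(=O)N(C)C)c1ccc(C)nc1C`). In an in vitro ADME assay on microsomes from liver (Homo sapiens) for metabolic stability (a higher number here means faster removal of the compound, a lower number slower removal), compound 1 gives 11000 mL.min-1.g-1, while compound 2 gives 7 mL.min-1.g-1. Compound 2 therefore stands lowest of the two numbers, and the gap lies well beyond the scatter. The two compounds differ in more than one place, so this gap cannot be assigned to any single structural change.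

The next compound is compound 3 (`CC[C@H](C)[C@@H]1C(=O)N[C@H](C2Cc3ccccc3C2)C(=O)N1[C@@H](C(=O)N(C)C)c1cnc(C)cc1C`). Its change from compound 2 is 4,6-dimethylpyridin-3-yl in place of 2,6-dimethylpyridin-3-yl on a saturated chain carbon bound to an amide-type nitrogen in a ring and a carbonyl carbon. For the measured compounds named here, no measured pair shows a swap of this kind, so the expectation starts from compound 2 at 7 mL.min-1.g-1 and carries wide uncertainty. The expected change is a 1.4-fold higher number from compound 2 to compound 3 (0.15 log units; within the scatter), which is estimated to stay within the scatter, with no clear direction. For compound 3 the estimated value in this assay is 10 mL.min-1.g-1, with an expected range of 3 mL.min-1.g-1 to 50 mL.min-1.g-1.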

Compound 3, intrinsic clearance in microsomes: 9 mL.min-1.g-1
The estimate for compound 3 lay 1.1-fold (0.05 log units) above the measured number, within the range that was stated.
By their numbers in this assay, from the lowest: compounds 2 and 3 (each within the scatter of the next); then compound 1.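

In this assay, among the compounds shown here, the change to 4,6-dimethylpyridin-3-yl in place of 2,6-dimethylpyridin-3-yl, on a saturated chain carbon bound to an amide-type nitrogen in a ring and a carbonyl carbon, is the first change that can be read in one place, and it comes out as a 1.3-fold higher number from compound 2 to compound 3 (0.11 log units; within the scatter). At this place, then, the two dimethylpyridin-3-yl isomers, which have the same atoms joined differently, cannot be told apart by this read-out, and the low number of compound 2 is not tied to the 2,6-dimethylpyridin-3-yl group alone. Nothing available explains why the two isomers sit so close.

Compound 1, at 11000 mL.min-1.g-1, differs from compound 2 and from compound 3 in more than one place, so the structural origin of its much higher number remains unassigned. Also open, going by these compounds, is whether the number would stay this low with a methoxy group, a chlorine atom or a trifluoromethyl group in place of either methyl on the dimethylpyridin-3-yl group.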